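A few compounds are considered here, and "the series" means these few. Any claim that something is new, unique, unknown or untested is made for them only; others in the source may bear on it.

Measured in a functional assay on MCF7 cells (Homo sapiens) for inhibition, read by MTT assay, with a stated time of 72 h; a higher number here means a weaker inhibitor, a lower number a stronger inhibitor:
- compound 1 `COc1ccc(NC(=O)C2CCN(C/C=C/c3ccccc3)CC2)cc1`: > 100000 nM
- compound 2 `O=C(Nc1cccc(Cl)c1)C1CCN(C/C=C/c2ccccc2)CC1`: 16100 nM

Compound 1 gives > 100000 nM, which is a limit of the assay and not a number. For the measured compounds named here, compound 2 therefore holds the only true number so far, 16100 nM.

Compound 3 `N#Cc1ccc(NC(=O)C2CCN(C/C=C/c3ccccc3)CC2)cc1` differs from compound 2 as follows: 4-cyanophenyl in place of 3-chlorophenyl on an amide-type nitrogen. It has 4-cyanophenyl in place of 3-chlorophenyl on an amide-type nitrogen.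

Going by the values given here, the one measured step bearing on this change is at the same nitrogen: an at least 6.2-fold lower number from compound 1 to compound 2 (0.79 log units; beyond the scatter). Its size is open on one side, and 3-chlorophenyl came with the lower number. Losing that group should therefore move the number partly back up.

The expected change is a 2.2-fold higher number from compound 2 to compound 3 (0.34 log units; beyond the scatter). For compound 3 the estimate is 35000 nM, with an expected range of 11000 nM to 100000 nM.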

Compound 3, half-maximal inhibitory concentration: 44500 nM
Compound 3: the middle estimate sits 1.3-fold (0.10 log units) below what was measured; low and high end bracket the measured number.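

In this assay, the change at this amide-type nitrogen gives a 2.8-fold higher number from compound 2 to compound 3 (0.44 log units; beyond the scatter), so 3-chlorophenyl in compound 2 keeps the lowest number of the three. Cyano in place of methoxy gives an at least 2.2-fold lower number from compound 1 to compound 3 (0.35 log units; beyond the scatter), so a measurable number at this nitrogen is not confined to 3-chlorophenyl. That step is open on one side, as compound 1 stands at a limit of the assay: the limit of > 100000 nM in this assay, at which 1 of the 3 values shown sits.

Compound 2 and compound 3 differ in both the group on the phenyl ring and its place, so those two remain unseparated. As far as these compounds go, how 4-chlorophenyl or 3-cyanophenyl would read remains open.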